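This account rests on a few compounds, and the source may have more. Where it says the series, first, only, none or still open, it means among the compounds named here.

Measured so far:
- compound 1, `Cc1cc(O)cc(-c2nn(CC#N)cc2-c2ccnc(-c3ccc(Oc4ccccc4)cc3)c2)c1`: 87%
- compound 2, `COc1cc(C)cc(-c2nn(CC#N)cc2-c2ccnc(-c3ccc(N(C)C)cc3)c2)c1`: -39%

In a functional assay on NCI-H522 cells (Homo sapiens) for cytotoxicity, read by sulforhodamine B assay, with a stated time of 48 h, tested at 100 nM (on this read-out lower numbers stand for a stronger effect and higher numbers for a weaker effect at the one concentration tested), compound 1 gives 87%, while compound 2 gives -39%. Compound 2 thus stands lowest of the two numbers, with compound 1 the nearest and higher by a gap beyond the scatter. Within the data shown here, the two differ in two places at once, so no single step between them can be read.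

Compound 3, `Cc1cc(O)cc(-c2nn(CC#N)cc2-c2ccnc(-c3ccc(N(C)C)cc3)c2)c1`, has not yet been measured. It differs from compound 2 in one place: hydrogen in place of methyl on an oxygen on an aromatic ring. The same change, taken one bond further out, reads methoxy to hydroxy on the 3-methoxy-5-methylphenyl ring. Among the measured compounds shown here, no measured pair shows this change on its own, so its effect cannot be read from the numbers at hand.

For compound 3 an upward step of a number 44 percentage points higher from compound 2 to compound 3 (beyond the scatter) is expected, though with wide uncertainty. Compound 3 is therefore estimated at 5%, in a range from -45% to 75%.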

Compound 3, a percentage reported as activity, at one concentration (the size of the read-out at that concentration, not a potency): 75%
Compound 3: middle estimate off by 70 percentage points, on the low side; measured number inside the range.
By their numbers in this assay, from the lowest: compound 2; then compound 3; then compound 1.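

In this assay, the change from methoxy to hydroxy on the 3-methoxy-5-methylphenyl ring can now be read on its own, and it gives a number 114 percentage points higher from compound 2 to compound 3 (beyond the scatter), a large step towards a weaker effect at the one concentration tested. With the hydroxy group held in place, dimethylamino in place of phenoxy on an aromatic carbon gives a number 12 percentage points lower from compound 1 to compound 3 (beyond the scatter), a modest step, so among these compounds the larger change is the one at the oxygen. Nothing at hand explains the size of either step.

The compounds shown leave open whether methoxy to hydroxy would count for as much with phenoxy in place of dimethylamino. They also leave open how an ethoxy group or an amine would read at this same place on the ring.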